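Fluoro substitution and tolerated concentration in a four-compound set

The source may hold more compounds than are shown below. What is called first, only, known or untested is meant among the compounds shown, and "the series" means these compounds.

Working notes on the series. Compound 1 `N#Cc1ccc2c(Cl)cc(Oc3ccccc3OCCn3ccc(=O)[nH]c3=O)cc2c1` is the reference. In a toxicity assay on MT2 cells (Homo sapiens) for cytotoxicity, read by MTT assay (a lower number here means that less compound is tolerated, a higher number that more compound is tolerated), compound 1 gives 12000 nM. Compound 2 `N#Cc1ccc2c(F)cc(Oc3ccccc3OCCn3ccc(=O)[nH]c3=O)c(Cl)c2c1` differs from compound 1 in its core; the difference between the two cores is not broken down here. Compound 2 gives only a limit of the assay, > 100000 nM, in this assay. Compound 3 `N#Cc1ccc2c(Cl)cc(Oc3ccc(F)cc3OCCn3ccc(=O)[nH]c3=O)cc2c1` carries the change fluoro in place of hydrogen on an aromatic carbon relative to compound 1. Compound 3 likewise gives only a limit of the assay, > 100000 nM, in this assay. The step of an at least 8.3-fold higher number from compound 1 to compound 3 (0.92 log units; beyond the scatter) is therefore read against a limit, and the evidence for the size of steps in this set rests on (the limit of > 100000 nM in this assay, at which 2 of the 3 values shown sit).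

Compound 4 `N#Cc1ccc2c(F)cc(Oc3ccc(F)cc3OCCn3ccc(=O)[nH]c3=O)c(Cl)c2c1` is not yet measured. It differs from compound 2 by fluoro in place of hydrogen on an aromatic carbon, the same change as from compound 1 to compound 3, and the place of the change is described in the same words in both pairs.

Compound 2 already sits at the limit of this assay, so the step to compound 4 cannot be resolved on the low side. On the strength of an at least 8.3-fold higher number from compound 1 to compound 3 (0.92 log units; beyond the scatter), compound 4 is expected to give 120000 nM in this assay, most likely reported only as a limit again. The expected step is a step that the limit leaves unreadable from compound 2 to compound 4, an estimate bounded by 60000 nM and 300000 nM.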

Compound 4, half-maximal cytotoxic concentration: 28000 nM
For compound 4 the middle estimate is 4.3-fold (0.63 log units) above the measured one, and the stated range ends above it.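

Fluoro in place of hydrogen on an aromatic carbon gives, in this assay, an at least 3.5-fold lower number from compound 2 to compound 4 (0.55 log units; beyond the scatter), so the change does not carry over from the core of compound 1 to the core of compound 2, in direction or in size: the same change on two cores in this assay, an at least 8.3-fold higher number (0.92 log units; beyond the scatter) from compound 1 to compound 3 and an at least 3.5-fold lower number (0.55 log units; beyond the scatter) from compound 2 to compound 4, at least 29-fold (1.47 log units) apart, beyond the scatter of two such steps

Compound 2 and compound 3 each stand only at a limit, so the opposite direction of the two steps is firm, while their full sizes remain unknown: the limit of > 100000 nM in this assay, at which 2 of the 4 values shown sit.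

The two pairs show that the result of this change depends on the core in this set, but they do not show which part of the core is responsible, and they give no rule for the series as a whole.

Still open, as far as these compounds go, is which of the differences between the two cores goes with the reversal, since each core is seen here only as a whole. Also open, from the compounds shown here alone, is whether another group in the same place, such as a methoxy group or an amine, would follow the same opposite course on the two cores, and whether a longer chain in place of the present one would change the picture.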